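A few compounds are considered here, and "the series" means these few. Any claim that something is new, unique, unknown or untested is made for them only; others in the source may bear on it.

Compound 1, with the structure `NC1=NC2(CCOCC2)N(OCCCOc2ccc(Cl)cc2)C(N)=N1`, carries a 4-chlorophenyl group at the end of its ether chain. In an assay on isolated protein for inhibition of Dihydrofolate reductase (Homo sapiens), read by spectrophotometry, using NADPH, with stated times of 5 s and 6 min, tested at 5 uM (a higher number here means a stronger effect of the compound at the concentration tested, a lower number a weaker effect), compound 1 gives > 90%, which is a limit of the assay rather than a number, so its true strength is known only to sit at or past that mark. Compound 3, with the structure `CC(C)(C)c1ccc(OCCCON2C(N)=NC(N)=NC23CCOCC3)cc1`, also gives > 90% in this assay, again a limit. The step from compound 1 to compound 3, a step that the two limits leave unreadable from compound 1 to compound 3, therefore cannot be read in size, since the limit of > 90% in this assay, at which 2 of the 3 values shown sit, holds both ends. Compound 2, the structure `CC(C)(C)c1ccc(OCCCON2C(N)=NC(N)=NC23CCSCC3)cc1`, differs from compound 3 only in the atom within its saturated ring, and in this assay compound 2 gives 85.3%.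

Compound 4 is the structure `Cc1cc(C)cc(OCCCON2C(N)=NC(N)=NC23CCOCC3)c1`, not yet measured. It differs from compound 1 by 3,5-dimethylphenyl in place of 4-chlorophenyl on an oxygen on a saturated carbon. Going by the values given here, no measured step changes the aryl group in a way whose size can be read, so nothing here points to a fall or a rise beyond the scatter. The expectation is that compound 4 stays close to the mark at which compound 1 sits, giving an estimated 88%, between 70% and 95%, with the expected step of a number at least 2 percentage points lower from compound 1 to compound 4 (that floor lies within the scatter).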

Compound 4, a percentage reported as inhibition, at one concentration (the size of the read-out at that concentration, not a potency): 84.3%
Beside the measured number, compound 4's estimate is 3.7 percentage points above it; low and high end bracket the measured number.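

With 3,5-dimethylphenyl in place of 4-chlorophenyl on an oxygen on a saturated carbon, a change of the aryl group at the end of the chain now has a step with a readable floor in this assay: a number at least 5.7 percentage points lower from compound 1 to compound 4 (that floor lies within the scatter). This shows that the chlorine is not needed for a substantial effect at the concentration tested, since an aryl group carrying only carbon substituents still gives a clear inhibition, though that floor alone does not establish a real loss. The true size of this step stays uncertain, and the step between the chloro and tert-butyl compounds cannot be read at all, because the upper end of the scale hides part of the series: the limit of > 90% in this assay, at which 2 of the 4 values shown sit.

The compounds shown leave open how an amine or a carboxylic acid on the aromatic ring would fare in this assay, and whether a longer chain in place of the present ether chain would keep the effect. Also open, going by these compounds, is whether a 4-methylphenyl group would behave like the 3,5-dimethylphenyl group of compound 4 or like the 4-chlorophenyl group of compound 1.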